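The source may report more compounds than this note shows. Statements on the series, on what has been measured and on what is new or still open speak of the compounds shown alone.

In an assay on mitochondria from L6 cells (Rattus norvegicus) for activation, with a stated time of 90 min (a higher number here means that more compound is needed for the effect, a lower number that less compound is needed), the measured compounds are:

Compound 1, `Oc1nc2nonc2nc1Nc1ccc(OCC(F)(F)F)cc1`: 42300 nM
Compound 2, `Oc1nc2nonc2nc1Nc1ccccc1`: 66700 nM
Compound 3, `CCCCCCc1ccc(Nc2nc3nonc3nc2O)cc1`: 4700 nM

Compound 3 stands lowest of the three numbers, since a 9.0-fold lower number from compound 1 to compound 3 (0.95 log units; beyond the scatter) and a 14-fold lower number from compound 2 to compound 3 (1.15 log units; beyond the scatter) both fall beyond the scatter, while a 1.6-fold higher number from compound 1 to compound 2 (0.20 log units; within the scatter) stays within it. Compound 4, `Oc1nc2nonc2nc1Nc1ccc(C(F)(F)F)cc1`, differs from compound 3 by trifluoromethyl in place of hexyl on an aromatic carbon. Going by the values given here, the steps that bear on this are the two that bring hexyl in, a 9.0-fold lower number from compound 1 to compound 3 (0.95 log units; beyond the scatter) and a 14-fold lower number from compound 2 to compound 3 (1.15 log units; beyond the scatter); taking hexyl out again should give back much of that gain, and compounds 1 and 2 show where other groups at that carbon have landed in this assay. The expected step is therefore a rise, a 6.4-fold higher number from compound 3 to compound 4 (0.81 log units; beyond the scatter). Compound 4 is expected at 30000 nM, between 10000 nM and 90000 nM in this assay.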

Compound 4, half-maximal effective concentration: 10400 nM
Compound 4: the middle estimate sits 2.9-fold (0.46 log units) above what was measured, and the stated range covers the measured number.
By their numbers in this assay, from the lowest: compound 3; then compound 4; then compounds 1 and 2 (each within the scatter of the next).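

In this assay, going by these compounds alone, hexyl is not the only group at this aromatic carbon that lowers the number: trifluoromethyl does so too relative to hydrogen, with a 6.4-fold lower number from compound 2 to compound 4 (0.81 log units; beyond the scatter), yet it keeps only part of the gain from hexyl, with a 2.2-fold higher number from compound 3 to compound 4 (0.34 log units; beyond the scatter) as the remaining gap. The two fluorinated groups also part clearly, with a 4.1-fold lower number from compound 1 to compound 4 (0.61 log units; beyond the scatter), even though 2,2,2-trifluoroethoxy stays within the scatter of hydrogen. No measurement shown here accounts for these differences. Open, as far as these compounds go, is whether a longer chain than hexyl would lower the number further, and how an amine or a carboxylic acid at this carbon would compare.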